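The source may hold more compounds than are shown below. What is called first, only, known or untested is meant among the compounds shown, and "the series" means these compounds.

In a functional assay on HCT-116 cells (Homo sapiens) for inhibition, read by sulforhodamine B assay, with a stated time of 72 h (a lower number here means a stronger inhibitor, a higher number a weaker inhibitor), two compounds have been measured so far:

Compound 1 `CC(c1ccc(-c2ccccc2)c(F)c1)c1nnc2n1N=C(c1ccccc1)CS2` gives 9700 nM.
Compound 2 `CC(C)Cc1ccc(C(C)c2nnc3n2N=C(c2ccc(Cl)cc2Cl)CS3)cc1` gives 11100 nM.

Of these two numbers that of compound 1 is the lower, but the gap to compound 2 is within the scatter of repeated measurements, so nothing separates the two compounds on this evidence. Among the compounds with values here, compound 2 also differs from compound 1 in more than one place, so no single step between measured compounds can be read from the pair.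

The next compound, compound 3 `CC(c1ccc(-c2ccccc2)c(F)c1)c1nnc2n1N=C(c1ccc([N+](=O)[O-])cc1)CS2`, is a direct variation of compound 1. Within the data shown here, the only change is nitro in place of hydrogen on an aromatic carbon; seen one bond further out, a phenyl becomes a 4-nitrophenyl on the shared core.

Among the measured compounds shown here, since no measured pair isolates this change, the size of the step is open. Compound 1 sits at 9700 nM, and a single added nitro group on an aromatic ring is not expected to move the number far. The estimated step is a 1.4-fold lower number from compound 1 to compound 3 (0.14 log units; within the scatter), a shift that may well stay inside the scatter. Compound 3 is therefore expected to give about 7000 nM in this assay, within a range from 2500 nM to 20000 nM.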

Compound 3, half-maximal inhibitory concentration: 7100 nM
Compound 3: the middle estimate sits 1.0-fold (0.01 log units) below what was measured; low and high end bracket the measured number.
By their numbers in this assay, from the lowest: compounds 3, 1 and 2 (each within the scatter of the next).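

In this assay, within the data shown here, the step of a 1.4-fold lower number from compound 1 to compound 3 (0.14 log units; within the scatter) is the first single change that can be read, since compounds 1 and 2 differ in more than one place. It shows that the phenyl on the shared core can become a 4-nitrophenyl, with the nitro group on an aromatic carbon para to a large group, while the number stays within the scatter of repeated measurements, so this change does not separate the two compounds on the present evidence. No measurement here explains this outcome or links it to any property of the nitro group.

Going by these compounds, it remains open whether another group at this same place, such as an amine, a carboxylic acid or a methoxy group, would produce a step that lies beyond the scatter rather than within it. Also open, on these data alone, is how the number would respond to a change elsewhere on compound 1, for example if a hydroxyl group or a longer chain took the place of the fluorine.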